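A Single Fluorine Added to Compound 2

The compounds below may be only part of what the source reports. "The series", "measured", "known", "first", "only" and "open" are said of these compounds alone.

Of the compounds shown here, two have been measured in a functional assay on Cortical neurone cells (Mus musculus, strain C57BL/6), read by FLIPR and calcium flux, with a stated time of 8 min; a lower number here means a stronger inhibitor, a higher number a weaker inhibitor. Compound 1, `CCCCCc1nc2[nH]c(-c3ccc(Cl)cc3)cc(=O)n2n1`, gives 8250 nM. Compound 2, `O=c1cc(-c2ccccc2)[nH]c2nc(Cc3ccccc3)nn12`, gives 1310 nM, the lowest of the two numbers; compound 1 stands a good way higher, beyond the usual scatter. Compound 3, `O=c1cc(-c2ccccc2)[nH]c2nc(Cc3ccc(F)cc3)nn12`, has not yet been measured in this assay. It differs from compound 2 in one place: fluoro in place of hydrogen on an aromatic carbon. Among the compounds with values here, no pair of measured compounds differs in a single place, so there is no measured step of this kind to lean on. With a change of one heavy atom, the step from compound 2 to compound 3 is expected to be none beyond the scatter, in either direction. The estimated step of a 1.2-fold lower number from compound 2 to compound 3 (0.08 log units; within the scatter) reflects this. Compound 3 is expected to give about 1100 nM in this assay, within 400 nM to 3000 nM.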

Compound 3, half-maximal inhibitory concentration: 2520 nM
The estimate for compound 3 lay 2.3-fold (0.36 log units) below the measured number, and the stated range covers the measured number.
By their numbers in this assay, from the lowest: compounds 2 and 3 (each within the scatter of the next); then compound 1.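

Within the data shown here, compound 1 and compound 2 differ in more than one place, so compound 3 gives the first comparison of a single change. In this assay, putting fluoro in place of hydrogen on this aromatic carbon, para to a large group, gives a 1.9-fold higher number from compound 2 to compound 3 (0.28 log units; within the scatter), so benzyl and 4-fluorobenzyl cannot be told apart here, and this place tolerates a single fluorine. Nothing available explains how the assay responds to this change.

One small atom at one place says little about what this position accepts overall. Going by these compounds, a methoxy group, an amine or a carboxylic acid at the same carbon could still move the number beyond the scatter, and whether the other ring responds in the same way remains open.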